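Placing a Bromo Group on Compound 1

The source may report more compounds than this note shows. Statements on the series, on what has been measured and on what is new or still open speak of the compounds shown alone.

Within the data shown here, in an ADME assay on CCRF-CEM cells (Homo sapiens), read by XTT assay, with a stated time of 72 h (on this read-out lower numbers stand for stronger inhibition and higher numbers for weaker inhibition), compound 1 `O=C1C=CC(=O)C1=Cc1ccccc1` gives 2600 nM, and its only measured neighbour, compound 2 `O=C1C=CC(=O)C1=Cc1ccc(F)cc1`, gives 1600 nM. The two values lie within the scatter of each other, so compound 1 has no clear standing above or below compound 2. Compound 3 `O=C1C=CC(=O)C1=Cc1cccc(Br)c1` differs from compound 1 by one change: bromo in place of hydrogen on an aromatic carbon, which is bromo in place of hydrogen on an aromatic carbon. Among the measured compounds shown here, one measured step bears on this, the exchange of fluoro for hydrogen on an aromatic carbon, a 1.6-fold lower number from compound 1 to compound 2 (0.21 log units; within the scatter), which stays within the scatter. For the measured compounds named here, no bromo compound has been measured yet, so this single step is limited support. In this assay, no clear shift beyond the scatter is expected, and the expected step is a 1.4-fold lower number from compound 1 to compound 3 (0.16 log units; within the scatter). Compound 3 is estimated at 1800 nM, with an expected range of 750 nM to 4200 nM.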

Compound 3, half-maximal inhibitory concentration: 7500 nM
For compound 3 the middle estimate is 4.2-fold (0.62 log units) below the measured one; the measured number lies above the stated range.
By their numbers in this assay, from the lowest: compounds 2 and 1 (each within the scatter of the next); then compound 3.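

In this assay, bromo in place of hydrogen on an aromatic carbon, meta to a group of 8 heavy atoms, gives a 2.9-fold higher number from compound 1 to compound 3 (0.46 log units; beyond the scatter), the first step from compound 1 to move beyond the scatter, and it runs toward weaker inhibition. A single halogen atom at this position is therefore enough to shift the number, which the fluoro exchange, with its step of a 1.6-fold lower number from compound 1 to compound 2 (0.21 log units; within the scatter) at a different ring carbon, gave no sign of. Nothing measured here bears on what lies behind this shift.

The compounds shown leave open whether the shift belongs to bromo itself or to its place on the ring. They also leave open how a methoxy group, an amine or a carboxylic acid at this same carbon would compare with bromo.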